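The source may hold more compounds than are shown below. What is called first, only, known or untested is meant among the compounds shown, and "the series" means these compounds.

Measured in a functional assay on SMMC-7721 cells (Homo sapiens) for antiproliferative activity, read by MTT assay, with a stated time of 48 h; on this read-out higher numbers stand for weaker inhibition and lower numbers for stronger inhibition:
Compound 1 `COC/C1=C/C[C@](C)(CCC=C(C)C)/C=C/[C@@H](OC(=O)C=C(C)C)[C@](C)(O)/C=C/C1=O`: 11000 nM
Compound 2 `CC(C)=CCC[C@]1(C)/C=C/[C@@H](OC(=O)C=C(C)C)[C@](C)(O)/C=C/C(=O)/C(C(=O)O)=C\C1`: > 10000 nM

For compound 2, the reading of > 10000 nM is a limit of this assay and not a number. Compound 3 `CC(C)=CCC[C@]1(C)/C=C/[C@@H](OC(=O)C=C(C)C)[C@](C)(O)/C=C/C(=O)/C(CCl)=C\C1` carries chloromethyl in place of carboxy on a double-bonded ring carbon. Going by the values given here, the only measured step at such a carbon is a step that the limit leaves unreadable from compound 1 to compound 2, so it offers no size to carry over. Among the compounds with values here, the sole number nearby is that of compound 1, which has methoxymethyl there and gives 11000 nM. A reading in that region is therefore expected, with no large change in this assay and only a modest move toward stronger inhibition. The expected step is an at least 1.4-fold lower number from compound 2 to compound 3 (0.15 log units; that floor lies within the scatter), and it remains a rough estimate. For compound 3, the estimated value is 7000 nM, with an expected range from 2000 nM to 20000 nM.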

Compound 3, half-maximal inhibitory concentration: 840 nM
Beside the measured number, compound 3's estimate is 8.3-fold (0.92 log units) above it, and the stated range ends above it.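

In this assay, chloromethyl on this double-bonded ring carbon gives an at least 11-fold lower number from compound 2 to compound 3 (1.07 log units; beyond the scatter), and chloro in place of methoxy on the saturated chain carbon bound to that ring carbon gives a 13-fold lower number from compound 1 to compound 3 (1.12 log units; beyond the scatter). The earlier pair gave no size at this position, as the step from compound 1 to compound 2 cannot be read, whereas these steps show that a change here can move the read-out by a large amount. The reading for compound 2 is a limit and not a number, so the step from it is only a floor because of that limit: the limit of > 10000 nM in this assay, at which 1 of the 3 values shown sits.

The compounds shown leave open whether chloro itself is needed on that chain carbon, or whether bromomethyl, hydroxymethyl or aminomethyl would give a similar number. They also leave open what a longer chain ending in chloro would do at this position.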